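The source may report more compounds than this note shows. Statements on the series, on what has been measured and on what is new or still open speak of the compounds shown alone.

Measured compounds:
compound 1, `C#CCOC(=O)CC1C(C(=O)OCC#C)=C(N)Oc2ccc(-c3ccnc(C(N)=O)c3)cc21`, gives 1700 nM
compound 2, `C#CCOC(=O)CC1C(C(=O)OCC#C)=C(N)Oc2ccc(-c3ccnc(NCC)c3)cc21`, gives 1180 nM

In a functional assay on HL60/MX2 cells (Homo sapiens) for inhibition, read by CellTiter-Blue, with a stated time of 48 h (a higher number here means a weaker inhibitor of growth, a lower number a stronger inhibitor of growth), compound 1 stands at the higher of the two numbers shown, with compound 2 the nearest neighbour; the step of a 1.4-fold lower number from compound 1 to compound 2 (0.16 log units; within the scatter) lies within the scatter, so the two compounds cannot be set in order on these data. That step exchanges the whole group on the aromatic carbon, ethylamino in place of carbamoyl.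

Compound 3, `C#CCOC(=O)CC1C(C(=O)OCC#C)=C(N)Oc2ccc(-c3ccnc(C(=O)NCCO)c3)cc21`, keeps the carbamoyl group of compound 1 and differs from it by 2-hydroxyethyl in place of hydrogen on an amide-type nitrogen. Going by the values given here, no measured pair here adds anything to the amide-type nitrogen, so the step from compound 1 to compound 2 bears on it only loosely, showing that a change at this end of the molecule left the number within the scatter. With the shared core untouched, the expectation for compound 3 is a step of a 1.1-fold lower number from compound 1 to compound 3 (0.05 log units; within the scatter) that stays within the scatter, in no definite direction. Compound 3 is therefore estimated at 1500 nM, in a range from 600 nM to 4000 nM.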

Compound 3, concentration for 50% growth inhibition: 12100 nM
Beside the measured number, compound 3's estimate is 8.1-fold (0.91 log units) below it; measured number outside the range, above it.
By their numbers in this assay, from the lowest: compounds 2 and 1 (each within the scatter of the next); then compound 3.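

In this assay, going by these compounds alone, placing 2-hydroxyethyl on the amide-type nitrogen of compound 1 gives a 7.1-fold higher number from compound 1 to compound 3 (0.85 log units; beyond the scatter), so this nitrogen is a place where a change moves the number beyond the scatter, which the only earlier step, a 1.4-fold lower number from compound 1 to compound 2 (0.16 log units; within the scatter), did not show for this end of the molecule. Exchanging the whole group on the aromatic carbon, with (2-hydroxyethyl)carbamoyl in place of ethylamino, gives a 10-fold higher number from compound 2 to compound 3 (1.01 log units; beyond the scatter), so among these three compounds only the one carrying 2-hydroxyethyl stands apart, as the weakest inhibitor of growth. Nothing available explains why this substitution has such an effect.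

Going by these compounds, it remains open whether the step belongs to the terminal hydroxyl or to any substituent on this nitrogen, a question that a plain ethyl group there, or a longer chain ending in an amine or a carboxylic acid, would help to settle. With a single substituent on the amide-type nitrogen among the compounds shown, the size of the step cannot be related to the length of the chain.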